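Acetamido on the benzyl ring of compound 1

The compounds below may be only part of what the source reports. "The series", "measured", "known", "first", "only" and "open" are said of these compounds alone.

Measured compounds:
compound 1 `c1ccc(CNCC2CCN(CCCc3c[nH]c4ccc(-n5cnnc5)cc34)CC2)cc1` — 28 nM
compound 2 `c1cc(CNC2CCN(CCCc3c[nH]c4ccc(-n5cnnc5)cc34)CC2)co1` — 78 nM

Within the data shown here, in an assay on CHO cells for displacement of a labelled ligand from 5-hydroxytryptamine receptor 1B (Homo sapiens) (on this read-out higher numbers stand for weaker inhibition and lower numbers for stronger inhibition), compound 1 gives the lowest of the two numbers; the only neighbour is compound 2, with a 2.8-fold higher number from compound 1 to compound 2 (0.44 log units; beyond the scatter). Among the measured compounds shown here, that step exchanges the whole benzyl end of the side chain and is the sole measured comparison in the set.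

Compound 3 `CC(=O)Nc1ccc(CNCC2CCN(CCCc3c[nH]c4ccc(-n5cnnc5)cc34)CC2)cc1` keeps the entire skeleton of compound 1 and adds a substituent to the benzyl ring: acetamido in place of hydrogen on an aromatic carbon. For the measured compounds named here, no measured pair varies a substituent on this ring, so the step from compound 1 to compound 2 does not bear directly on the change; it only shows that alterations at this end of the molecule moved the read-out in this assay by a modest amount. With nothing to anchor the direction, the step to compound 3 is expected to stay small, a 1.1-fold higher number from compound 1 to compound 3 (0.03 log units; within the scatter), with the range kept wide to allow for a modest shift either way. Compound 3 is therefore estimated at 30 nM, between 10 nM and 90 nM, in this assay.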

Compound 3, half-maximal inhibitory concentration: 8.9 nM
Compound 3: middle estimate off by 3.4-fold (0.53 log units), on the high side; the measured number lies below the stated range.
By their numbers in this assay, from the lowest: compound 3; then compound 1; then compound 2.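

In this assay, the benzyl ring of compound 1 accepts a substituent para to a large group: acetamido in place of hydrogen gives a 3.1-fold lower number from compound 1 to compound 3 (0.50 log units; beyond the scatter), a modest step that lies beyond the usual scatter. The earlier comparison exchanged the whole benzyl end of the side chain, whereas this one keeps the skeleton intact and isolates a single aromatic carbon, showing that the read-out responds to substitution at this position and that the added atoms here go with a lower number rather than a higher one. Nothing available gives a reason for this shift.

Still open, going by these compounds, is whether the lower number belongs to acetamido in particular or would also follow from a free amine, a methoxy group, a carboxylic acid or a longer acyl chain such as propionamido at the same carbon. On these data alone, it is equally open whether acetamido would give a step of similar direction and size on the furan ring of compound 2, where the side chain also differs.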